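The compounds below may be only part of what the source reports. "The series", "measured", "known", "first", "only" and "open" are said of these compounds alone.

- compound 1 `COc1cc(/C=C2\C(=O)Nc3ccc(Cl)cc32)ccc1OCCCN1CC(C)OC(C)C1`: 2770 nM
- compound 2 `COc1cc(/C=C2\C(=O)Nc3ccc(Cl)cc32)ccc1OCCCN1CCN(c2ccccn2)CC1`: > 20000 nM (a limit of the assay)
- compound 3 `COc1cc(/C=C2\C(=O)Nc3ccc(Cl)cc32)ccc1OCCCN1CCN(c2ncccc2C(F)(F)F)CC1`: 1530 nM

In a functional assay on BT-549 cells (Homo sapiens) for cytotoxicity, read by MTT assay, with a stated time of 48 h (on this read-out lower numbers stand for stronger inhibition and higher numbers for weaker inhibition), compound 3 gives 1530 nM, which lies within the usual scatter of compound 1 at 2770 nM. Compound 2 reports > 20000 nM, which is a limit and not a number.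

Compound 4 `COc1cc(/C=C2\C(=O)Nc3ccc(Cl)cc32)ccc1OCCCN1CCN(C)CC1` differs from compound 3 as follows: methyl in place of 3-(trifluoromethyl)pyridin-2-yl on an amine nitrogen in a ring. It carries methyl in place of 3-(trifluoromethyl)pyridin-2-yl on an amine nitrogen in a ring.

Within the data shown here, two measured steps bear on this change, and neither measures it directly. The large step of an at least 13-fold lower number from compound 2 to compound 3 (1.11 log units; beyond the scatter) came with trifluoromethyl in place of hydrogen on an aromatic carbon, so the number responded strongly to a small edit of the group that compound 4 loses. The step of an at least 7.2-fold higher number from compound 1 to compound 2 (0.85 log units; beyond the scatter) is at least modest and exchanged 2,6-dimethylmorpholin-4-yl for 4-(pyridin-2-yl)piperazin-1-yl. Compound 1 has no aromatic group in that part of the molecule and still gives 2770 nM, so the loss need not be severe.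

A modest rise is therefore expected in this assay, although the direction is not secure. The estimated step is a 2.6-fold higher number from compound 3 to compound 4 (0.42 log units; beyond the scatter). Compound 4 is expected to give 4000 nM, with an estimated range from 1200 nM to 15000 nM.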

Compound 4, half-maximal inhibitory concentration: 2170 nM
The estimate for compound 4 lay 1.8-fold (0.27 log units) above the measured number, within the range that was stated.
By their numbers in this assay, from the lowest: compounds 3, 4 and 1 (each within the scatter of the next). At a limit, above all of these: compound 2.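

In this assay, among these compounds, the earlier compounds left it unclear whether an aromatic group on the amine nitrogen in the ring matters, and compound 4 shows that a plain methyl there serves as well as 3-(trifluoromethyl)pyridin-2-yl: the exchange gives a 1.4-fold higher number from compound 3 to compound 4 (0.15 log units; within the scatter), and the exchange of 2,6-dimethylmorpholin-4-yl for 4-methylpiperazin-1-yl gives a 1.3-fold lower number from compound 1 to compound 4 (0.11 log units; within the scatter). The loss of activity thus belongs to the unsubstituted pyridin-2-yl group of compound 2 rather than to the amine nitrogen or to the removal of a large group, as methyl in its place gives an at least 9.2-fold lower number from compound 2 to compound 4 (0.96 log units; beyond the scatter). Compound 2 is the only one of these reported as a limit of the assay and not as a number: the limit of > 20000 nM in this assay, at which 1 of the 4 values shown sits.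

The compounds shown leave open whether other groups on this nitrogen, such as an ethyl, an acetyl or an unsubstituted phenyl, would also stay within the scatter of compound 4. They also leave open whether a free secondary amine at this position, or a longer chain linking it to the oxygen on the aromatic ring, would move the number in this assay.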